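The source may hold more compounds than are shown below. What is called first, only, known or untested is meant among the compounds shown, and "the series" means these compounds.

Among the compounds with values here, in a functional assay (plasma) for inhibition, with Homo sapiens as the target (on this read-out higher numbers stand for weaker inhibition and lower numbers for stronger inhibition), compound 1 `Cc1ccc(S(=O)(=O)N[C@H]2CC[C@H](O)[C@@H]2C/C=C\CCC(=O)O)cc1` gives 2500 nM, the highest of the three numbers so far. Compound 2 `O=C(O)CC/C=C\C[C@@H]1[C@@H](NS(=O)(=O)c2ccc(Cl)cc2)CC[C@@H]1O` gives 1800 nM. Within the data shown here, the only measured step, a 1.4-fold lower number from compound 1 to compound 2 (0.14 log units; within the scatter), is a change on an aromatic carbon and leaves the carboxy-bearing chain untouched, so it bears little on the chain. Compound 3 `O=C(O)CCC/C=C\C[C@H]1/C(=N/OCc2ccc(C(F)(F)F)cc2)CC[C@@H]1NS(=O)(=O)c1ccc(F)cc1` gives 620 nM, lower than compound 1 and beyond the scatter. It carries the 5-carboxypent-1-en-1-yl chain but also differs from compound 1 elsewhere.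

Compound 4 `Cc1ccc(S(=O)(=O)N[C@H]2CC[C@H](O)[C@@H]2C/C=C\CCCC(=O)O)cc1` keeps the core of compound 1 and changes the chain: carboxymethyl in place of carboxy on a saturated chain carbon, two bonds along the chain from a double-bonded chain carbon. Among the measured compounds shown here, no measured step isolates this change. With compound 3 at 620 nM as the only, weak, pointer, a modest move to a lower number is expected. The expected step is a 2.5-fold lower number from compound 1 to compound 4 (0.40 log units; beyond the scatter). For compound 4 the estimate is 1000 nM, with an expected range of 300 nM to 3000 nM.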

Compound 4, half-maximal inhibitory concentration: 500 nM
Beside the measured number, compound 4's estimate is 2.0-fold (0.30 log units) above it; the range from low to high includes it.
By their numbers in this assay, from the lowest: compounds 4 and 3 (each within the scatter of the next); then compounds 2 and 1 (each within the scatter of the next).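

With the core of compound 1 held constant, extending 4-carboxybut-1-en-1-yl to 5-carboxypent-1-en-1-yl gives in this assay a 5.0-fold lower number from compound 1 to compound 4 (0.70 log units; beyond the scatter) and is beyond the scatter. Within the data shown here, this is the first reading of the chain on its own, as compound 3 carries the same chain but also differs elsewhere. The number at this position therefore responds to a change in chain length alone, but no measurement here gives a reason for the shift.

Going by these compounds, whether a longer chain, such as 6-carboxyhex-1-en-1-yl, would continue or reverse this move remains open from these two lengths. Also open, on these data alone, are a tetrazole in place of the carboxylic acid on the 5-carboxypent-1-en-1-yl chain and whether the chloro group of compound 2 would combine with that chain.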